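Amino-acid variation on a shared core: compound 4

The compounds below may be only part of what the source reports. "The series", "measured", "known", "first", "only" and "open" are said of these compounds alone.

Among the measured compounds shown here, compound 3 `CC(C)[C@H](NC(=O)CN(c1nc(Cl)nc2[nH]cnc12)C1CC1)C(=O)O` stands second highest of the three numbers so far in a functional assay on the whole organism (Tail, strain ICR) with Mus musculus as the target, in the tail flick test, with a stated time of 120 min, at a dose of 25 umol/kg by the oral route (on this read-out higher numbers stand for a stronger effect at the one dose given and lower numbers for a weaker effect), where compound 3 gives 17.1%. Its nearest neighbour is compound 1 `N=C(N)NCCC[C@H](NC(=O)CN(c1nc(Cl)nc2[nH]cnc12)C1CC1)C(=O)O`, which in this assay gives 17%, a gap within the scatter. Furthest away is compound 2 `O=C(CN(c1nc(Cl)nc2[nH]cnc12)C1CC1)N[C@@H](CO)C(=O)O`, which in this assay gives 39%, beyond the scatter above compound 3.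

Compound 4 `CSCC[C@H](NC(=O)CN(c1nc(Cl)nc2[nH]cnc12)C1CC1)C(=O)O` is the next member of the series and differs from compound 3 by 2-(methylsulfanyl)ethyl in place of isopropyl on a saturated chain carbon bound to an amide-type nitrogen and a carbonyl carbon.

For the measured compounds named here, two measured steps alter the same saturated chain carbon bound to an amide-type nitrogen and a carbonyl carbon. a number 21.9 percentage points lower from compound 2 to compound 3 (beyond the scatter), so hydroxymethyl at this place sits clearly higher than isopropyl. a number 0.1 percentage points higher from compound 1 to compound 3 (within the scatter), so the group that leaves in that step and isopropyl cannot be told apart here. 2-(methylsulfanyl)ethyl has no precedent, and nothing in the measured steps points in either direction for it. The expectation is therefore a step of a number 2.9 percentage points higher from compound 3 to compound 4 (within the scatter), not beyond the scatter.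

Compound 4 is estimated at 20% in this assay, with a range from 8% to 35%.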

Compound 4, a percentage reported as activity, at one dose (the size of the read-out at that dose, not a potency): 5.67%
Beside the measured number, compound 4's estimate is 14.3 percentage points above it; the measured number lies below the stated range.
By their numbers in this assay, from the lowest: compound 4; then compounds 1 and 3 (each within the scatter of the next); then compound 2.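

In this assay, among the compounds shown here, the saturated chain carbon bound to an amide-type nitrogen and a carbonyl carbon now shows a drop as well as a rise: with 2-(methylsulfanyl)ethyl in place of isopropyl there is a number 11.4 percentage points lower from compound 3 to compound 4 (beyond the scatter) in the series, the first change at this place to fall below the level of isopropyl. The same low position appears in a number 11.3 percentage points lower from compound 1 to compound 4 (beyond the scatter) and in a number 33.3 percentage points lower from compound 2 to compound 4 (beyond the scatter), so the series now spans three separate levels at this one place, with the hydroxymethyl group highest and the 2-(methylsulfanyl)ethyl group lowest. Group size alone does not order these numbers, since the side chain of compound 1 is larger than 2-(methylsulfanyl)ethyl and still stands higher, and no measurement shown bears on the reason for the drop.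

From the compounds shown here alone, whether the fall follows the sulfur or the chain length stays open, and an n-butyl or n-propyl chain at this place would separate the two. Also open, going by these compounds, is where an amine, a second carboxylic acid or an amide side chain would fall relative to hydroxymethyl, and whether this order holds at other doses and times.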